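The compounds below may be only part of what the source reports. "The series", "measured", "known", "first", "only" and "open" are said of these compounds alone.

Compound 1 `O=C1C(N2CCCCC2)=CC(=O)c2c1nc1n2[C@H]2OC[C@@H](O)[C@H]2OC1` is known in a functional assay on MGC-803 cells (Homo sapiens) for inhibition, read by sulforhodamine B assay (a higher number here means a weaker inhibitor, a lower number a stronger inhibitor), only as a limit, reported as > 4000 nM. This places compound 1 at the limit of > 4000 nM in this assay, at which 1 of the 2 values shown sits. Compound 2 `Cc1ccc(NC2=CC(=O)c3nc4n(c3C2=O)[C@H]2OC[C@@H](O)[C@H]2OC4)cc1` gives a number in this assay, 1420 nM. Compound 3 `O=C1C(Nc2cccc(F)c2)=CC(=O)c2c1nc1n2[C@H]2OC[C@@H](O)[C@H]2OC1` is still to be measured; it differs from compound 1 by (3-fluorophenyl)amino in place of piperidin-1-yl on a double-bonded ring carbon. Among the measured compounds shown here, no single-change step between measured compounds exists here, so the size of this move rests on the structures alone: the entering group resembles the substituent carried by compound 2 more than piperidin-1-yl does, so a gain in potency beyond the scatter is expected, estimated as an at least 2.6-fold lower number from compound 1 to compound 3 (0.42 log units; beyond the scatter). Compound 3 is expected at 1500 nM, in a range from 500 nM to 4500 nM.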

Compound 3, half-maximal inhibitory concentration: 1470 nM
For compound 3 the middle estimate is 1.0-fold (0.01 log units) above the measured one; the range from low to high includes it.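

In this assay, (3-fluorophenyl)amino in place of piperidin-1-yl on a double-bonded ring carbon gives an at least 2.7-fold lower number from compound 1 to compound 3 (0.43 log units; beyond the scatter) and so shows that potency at this position responds to the substituent. The size of this step is only a bound, because the value of compound 1 is a limit: the limit of > 4000 nM in this assay, at which 1 of the 3 values shown sits.

The compounds shown leave open whether the gain follows the aromatic ring or the hydrogen-bond donor. A cyclohexylamino group, which keeps the donor on a non-aromatic ring, would separate the two.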